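The source may report more compounds than this note shows. Statements on the series, on what has been measured and on what is new or still open speak of the compounds shown alone.

For the measured compounds named here, in a functional assay on MCF7 cells (Homo sapiens) for antiproliferative activity, with a stated time of 72 h (on this read-out higher numbers stand for weaker inhibition and lower numbers for stronger inhibition), compound 1 `COc1ccccc1/C=C/c1nc(Nc2cccc(O)c2)c2ccccc2n1` gives 11200 nM and compound 2 `COc1ccc(/C=C/c2nc(Nc3cccc(O)c3)c3ccccc3n2)cc1` gives 14700 nM, so compound 2 stands within the scatter of the only other measured value. Compound 3 `O=[N+]([O-])c1cccc(/C=C/c2nc(Nc3cccc(O)c3)c3ccccc3n2)c1` has 3-nitrophenyl in place of 4-methoxyphenyl on a double-bonded chain carbon bound to a double-bonded chain carbon. Going by the values given here, the one measured step that bears on this, a 1.3-fold higher number from compound 1 to compound 2 (0.12 log units; within the scatter), exchanged 2-methoxyphenyl for 4-methoxyphenyl and involved no nitro group, so it is only a weak guide. No change beyond the scatter is expected in this assay, and the estimated step is a 1.1-fold lower number from compound 2 to compound 3 (0.05 log units; within the scatter). Compound 3 is expected at 13000 nM, with an estimated range of 4500 nM to 38000 nM.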

Compound 3, half-maximal inhibitory concentration: 10100 nM
Beside the measured number, compound 3's estimate is 1.3-fold (0.11 log units) above it; the measured number falls inside the stated range.
By their numbers in this assay, from the lowest: compounds 3, 1 and 2 (each within the scatter of the next).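

In this assay, 3-nitrophenyl on a double-bonded chain carbon bound to a double-bonded chain carbon gives a number that cannot be told apart from those of both methoxyphenyl compounds (a 1.5-fold lower number from compound 2 to compound 3 (0.16 log units; within the scatter)) and (a 1.1-fold lower number from compound 1 to compound 3 (0.04 log units; within the scatter)). This place has therefore now carried a nitro group as well as a methoxy group without a change beyond the scatter. Nothing measured here gives a reason for this flat result. Still open, on these data alone, is whether an amine or a carboxylic acid on this phenyl ring would move the number beyond the scatter.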